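Benzoyl in Place of the Carbamate at the Ring Nitrogen

The source may hold more compounds than are shown below. What is called first, only, known or untested is meant among the compounds shown, and "the series" means these compounds.

Compound 1: `CCOC(=O)N1CCCc2cc(S(=O)(=O)N3CC(c4ccccc4)NC3=O)ccc21` — 344 nM
Compound 2: `O=C(OCCCl)N1CCCc2cc(S(=O)(=O)N3CC(c4ccccc4)NC3=O)ccc21` — > 20000 nM (a limit)

Of the compounds shown here, two sharing one core have been measured in a functional assay on A549 cells (Homo sapiens) for antiproliferative activity, read by MTT assay; a higher number here means a weaker inhibitor, a lower number a stronger inhibitor. Compound 1 gives 344 nM. Compound 2 gives only a limit, > 20000 nM, so for compound 2 the number itself is not known; the limit of > 20000 nM in this assay, at which 1 of the 2 values shown sits, marks this. Among the compounds with values here, the one measured step, an at least 58-fold higher number from compound 1 to compound 2 (1.76 log units; beyond the scatter), shows how a small change on the carbamate chain can cost a great deal.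

Compound 3, `O=C(c1ccccc1)N1CCCc2cc(S(=O)(=O)N3CC(c4ccccc4)NC3=O)ccc21`, differs from compound 2 by phenyl in place of 2-chloroethoxy on a carbonyl carbon. Within the data shown here, no measured step mirrors this change, and the only step at hand, an at least 58-fold higher number from compound 1 to compound 2 (1.76 log units; beyond the scatter), speaks to a different part of the same group. With compound 2 at a limit, any recovery appears as a lower number. Compound 3 is estimated at 4000 nM, between 400 nM and 20000 nM, and the expected step of an at least 5.0-fold lower number from compound 2 to compound 3 (0.69 log units; beyond the scatter) is thus a move toward compound 1, though a wide one.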

Compound 3, half-maximal inhibitory concentration: 8140 nM
Estimate against measurement, compound 3: 2.0-fold (0.31 log units) below; measured number inside the range.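

Compound 3 shows that the carbonyl carbon on the amide-type nitrogen in a ring can carry phenyl, with no oxygen or chlorine in the group, and still give a measured number in this assay. Set against the 2-chloroethoxy group, phenyl brings back some activity (an at least 2.4-fold lower number from compound 2 to compound 3 (0.39 log units; beyond the scatter)), but it does not match the ethoxy group (a 24-fold higher number from compound 1 to compound 3 (1.37 log units; beyond the scatter)). Of the three groups shown on this carbonyl carbon, ethoxy therefore gives the lowest number, and both other groups lie well beyond the scatter from it.

Going by these compounds, whether a methoxy group, a longer chain or an amine on this carbonyl carbon would come closer to compound 1 remains open. Compound 2 is held only as a limit (> 20000 nM), so the full size of the recovery with phenyl stays unknown: the limit of > 20000 nM in this assay, at which 1 of the 3 values shown sits.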